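Benzyl amide variations on the pyrazole-linked dihydroxyheptanoic acid series

This account rests on a few compounds, and the source may have more. Where it says the series, first, only, none or still open, it means among the compounds named here.

Measured so far:
compound 1 `CC(C)c1c(C(=O)NCc2ccccn2)nn(-c2ccc(F)cc2)c1OC[C@@H](O)C[C@@H](O)CC(=O)O`: 25 nM
compound 2 `CC(C)c1c(C(=O)NCc2ccc(Cl)cc2)nn(-c2ccc(F)cc2)c1OC[C@@H](O)C[C@@H](O)CC(=O)O`: 6.7 nM
compound 3 `CC(C)c1c(C(=O)NCc2ccccc2Cl)nn(-c2ccc(F)cc2)c1OC[C@@H](O)C[C@@H](O)CC(=O)O`: 9.5 nM

Compound 3 stands second highest of the three numbers in an assay on microsomes from liver for inhibition of 3-hydroxy-3-methylglutaryl-coenzyme A reductase (Rattus norvegicus); a lower number here means a stronger inhibitor, a higher number a weaker inhibitor; its nearest neighbour is compound 2 with a 1.4-fold higher number from compound 2 to compound 3 (0.15 log units; within the scatter), the furthest is compound 1 with a 2.6-fold lower number from compound 1 to compound 3 (0.42 log units; beyond the scatter).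

Compound 4 `CC(C)c1c(C(=O)N(C)Cc2cccc(F)c2)nn(-c2ccc(F)cc2)c1OC[C@@H](O)C[C@@H](O)CC(=O)O` differs from compound 3 by (3-fluorobenzyl)(methyl)amino in place of (2-chlorobenzyl)amino on a carbonyl carbon. Two things move at once: the halogen on the benzyl ring changes kind and position, and the amide nitrogen gains a methyl group. The measured steps bear only on the first part. Moving the chlorine around the ring gave a 1.4-fold higher number from compound 2 to compound 3 (0.15 log units; within the scatter), and swapping pyridin-2-yl for a chlorophenyl gave a 3.7-fold lower number from compound 1 to compound 2 (0.57 log units; beyond the scatter) and a 2.6-fold lower number from compound 1 to compound 3 (0.42 log units; beyond the scatter); halogenated benzyl groups therefore sit close together. Going by the values given here, no measured pair tests the methyl on the amide nitrogen, so that part of the change is uncovered. On the halogen part alone, the expected step from compound 3 to compound 4 is a 1.5-fold higher number from compound 3 to compound 4 (0.17 log units; within the scatter), roughly within the scatter, with the uncertainty widened for the untested methyl. For compound 4 the estimate in this assay is 14 nM, with a range from 5 nM to 45 nM.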

Compound 4, half-maximal inhibitory concentration: 14 nM
Compound 4: the middle estimate sits on the measured number at the digits printed, within the range that was stated.
By their numbers in this assay, from the lowest: compounds 2, 3, 4 and 1 (each within the scatter of the next, the first and the last beyond it).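

In this assay the change to (3-fluorobenzyl)(methyl)amino on the carbonyl carbon gives a 1.5-fold higher number from compound 3 to compound 4 (0.17 log units; within the scatter) and so shows that this position accepts the loss of the amide hydrogen, at least when the halogen changes with it. Compound 4 is separated only from the (4-chlorobenzyl)amino amide, by a 2.1-fold higher number from compound 2 to compound 4 (0.32 log units; beyond the scatter) and a modest step, while a 1.8-fold lower number from compound 1 to compound 4 (0.25 log units; within the scatter) leaves it within the scatter of the pyridine amide too, even though compound 1 and compound 3 lie apart. No supporting data on these steps are available.

Going by these compounds, the methyl and the halogen move together here, so their separate contributions stay open; (3-fluorobenzyl)amino and (2-chlorobenzyl)(methyl)amino would divide them. On these data alone, how a longer chain between the amide nitrogen and the aromatic ring would read at this carbonyl carbon also remains open.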